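A few compounds are considered here, and "the series" means these few. Any claim that something is new, unique, unknown or untested is made for them only; others in the source may bear on it.

Compounds measured so far:
- compound 1, `N/C(=N\NC(=S)N1CCCCCC1)c1ccccn1`: 76.5%
- compound 2, `Cc1cccc(/C(N)=N/NC(=S)N2CCCCC2)n1`: 43%
- compound 3, `Cc1ccnc(/C(N)=N/NC(=S)N2CCCCCC2)c1`: 75.9%

In a functional assay on MCF7 cells (Homo sapiens) for cytotoxicity, read by MTT assay, with a stated time of 72 h, tested at 30 uM (a lower number here means less inhibition of growth, a higher number more inhibition of growth at the concentration tested), compound 1 gives 76.5%, the highest of the three numbers; compound 3 sits closest, and the step of a number 0.6 percentage points lower from compound 1 to compound 3 (within the scatter) is within the scatter, while compound 2 sits furthest, its value lying beyond the scatter from that of compound 1.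

Compound 4, `Cc1cccc(/C(N)=N/NC(=S)N2CCCCCC2)n1`, has not yet been measured in this assay. It differs from compound 1 by methyl in place of hydrogen on an aromatic carbon. Going by the values given here, only one measured step bears directly on this change: a number 0.6 percentage points lower from compound 1 to compound 3 (within the scatter), a methyl placed on another aromatic carbon of the same ring, which left the number unchanged within the scatter. Compound 2, however, carries the methyl at the same place as compound 4 but differs from it elsewhere, and compound 2 gives only 43% in this assay. Because of a number 0.6 percentage points lower from compound 1 to compound 3 (within the scatter) no large step is expected, but the low value of compound 2 keeps the downward side open. Compound 4 is therefore expected to give about 65%, within 40% to 82%, an expected step of a number 11.5 percentage points lower from compound 1 to compound 4 (beyond the scatter).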

Compound 4, percent growth inhibition at one concentration: 38.8%
Compound 4: the middle estimate sits 26.2 percentage points above what was measured, and the stated range ends above it.
By their numbers in this assay, from the lowest: compounds 4 and 2 (each within the scatter of the next); then compounds 3 and 1 (each within the scatter of the next).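

In this assay, a methyl next to the ring nitrogen is far from a neutral replacement for hydrogen: the change gives a number 37.7 percentage points lower from compound 1 to compound 4 (beyond the scatter), whereas a methyl on another aromatic carbon of the same ring gives a number 0.6 percentage points lower from compound 1 to compound 3 (within the scatter). Across compounds 1, 3 and 4, the effect of adding a methyl therefore depends on which ring carbon carries it, and the carbon next to the ring nitrogen is the one where the number falls. Nothing available bears on why the number falls at this carbon.

The compounds shown leave open whether the fall belongs to the methyl itself or would also follow a different group at this carbon. A fluorine atom, a methoxy group or an ethyl group here could show how far the result depends on the group that enters.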